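The compounds below may be only part of what the source reports. "The series", "measured", "known", "first", "only" and "open" are said of these compounds alone.

Notes on the series. Compound 1 `CN(C)C(=O)c1cc2cnc(Nc3ccc(C(=O)NCCCN=C=S)cc3F)nc2n1C1CCCC1` and compound 2 `CN(C)C(=O)c1cc2cnc(Nc3ccc(C(=O)NCCCN=C=S)cc3O)nc2n1C1CCCC1` share one core and differ at a single aromatic carbon. In a functional assay on NCI-H1299 cells (Homo sapiens) for inhibition, read by CCK-8 assay, with a stated time of 72 h, tested at 10 uM (on this read-out lower numbers stand for a weaker effect and higher numbers for a stronger effect at the one concentration tested), compound 1 gives 78.5%, while compound 2 gives 24.2%. Among the compounds with values here, the one measured step, a number 54.3 percentage points lower from compound 1 to compound 2 (beyond the scatter), is the hydroxy in place of fluoro on an aromatic carbon. On the two numbers available, compound 2 stands lowest; its nearest neighbour is compound 1, higher by a margin beyond the scatter.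

Compound 3 `CN(C)C(=O)c1cc2cnc(Nc3ccc(C(=O)NCCCCCN=C=S)cc3O)nc2n1C1CCCC1` keeps the hydroxy of compound 2 and alters the chain: a group of 5 heavy atoms (3 carbon, 1 nitrogen, 1 sulfur; no ring) in place of a group of 3 heavy atoms (1 carbon, 1 nitrogen, 1 sulfur; no ring), on a saturated chain carbon, three bonds along the chain from an amide-type nitrogen. The change sits on a saturated chain carbon, three bonds along the chain from an amide-type nitrogen. Within the data shown here, no measured step touches that chain; the only step measured concerns the aromatic substituent and does not bear on it. Nothing here points to a direction, so for compound 3 the expected step is a number 2.8 percentage points higher from compound 2 to compound 3 (within the scatter), within the scatter. Compound 3 is accordingly estimated at 27% in this assay, with a range from 8% to 52%.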

Compound 3, a percentage reported as inhibition, at one concentration (the size of the read-out at that concentration, not a potency): 80.7%
Compound 3: the middle estimate sits 53.7 percentage points below what was measured; the measured number lies above the stated range.
By their numbers in this assay, from the lowest: compound 2; then compounds 1 and 3 (each within the scatter of the next).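

In this assay, the saturated chain carbon, three bonds along the chain from an amide-type nitrogen, proves to be a position of large effect: a group of 5 heavy atoms (3 carbon, 1 nitrogen, 1 sulfur; no ring) in place of a group of 3 heavy atoms (1 carbon, 1 nitrogen, 1 sulfur; no ring) gives a number 56.5 percentage points higher from compound 2 to compound 3 (beyond the scatter). The earlier step, a number 54.3 percentage points lower from compound 1 to compound 2 (beyond the scatter), concerned only the aromatic substituent, whereas the new pair shows that a low number is not fixed by the hydroxy alone, since compound 3 keeps that hydroxy and gives 80.7%. No supporting data accompany this pair, so the reason for the size of the step remains unknown.

The compounds shown leave open how the group of 5 heavy atoms behaves with fluoro in place of the hydroxy, and therefore whether the aromatic and chain changes act independently. They also leave open whether the trend extends to a longer chain, or whether an amine in place of the group of 5 heavy atoms would keep the higher number at the one concentration tested.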